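This account rests on a few compounds, and the source may have more. Where it says the series, first, only, none or still open, it means among the compounds named here.

Measured so far:
compound 1, `N#Cc1cnc(NCc2cnccc2C(F)(F)F)cc1NC[C@H]1CC[C@@H](O)CC1`, 500 nM in an assay on isolated protein for inhibition of protein kinase C delta type (Homo sapiens), read by TR-FRET, with a stated time of 2 h; a higher number here means a weaker inhibitor, a lower number a stronger inhibitor
compound 2, `N#Cc1cnc(NCc2cnccc2C(F)(F)F)cc1NCC1CCOCC1`, 5000 nM in this assay

Compound 2 stands at the highest of the two numbers; its nearest neighbour is compound 1, and the step of a 10-fold higher number from compound 1 to compound 2 (1.00 log units; beyond the scatter) lies beyond the scatter. The unmeasured compound 3 is `N#Cc1cnc(NCc2cnccc2C(F)(F)F)cc1NCCC1CCOCC1`. It differs from compound 2 by (oxan-4-yl)methyl in place of oxan-4-yl on a saturated chain carbon bound to a nitrogen on an aromatic ring, so the oxanyl ring is pushed one bond further from the nitrogen on the aromatic ring. Among the measured compounds shown here, only one measured step exists, a 10-fold higher number from compound 1 to compound 2 (1.00 log units; beyond the scatter), and it concerns a swap of ring rather than a lengthening of the chain, so it bears on this change only indirectly. For the measured compounds named here, no measured pair shows what a longer chain at this position does. The step from compound 2 to compound 3 is therefore expected to be no larger than a modest one in either direction, most likely within the scatter, as no change at the digits printed from compound 2 to compound 3 (within the scatter). Compound 3 is thus estimated at 5000 nM in this assay, with a range from 1500 nM to 16000 nM.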

Compound 3, half-maximal inhibitory concentration: > 10000 nM
Compound 3: only a limit was reported; the forecaster's own chance of this, stated with the estimate: 10%; middle value at least 2.0-fold (0.30 log units) from the limit.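

In this assay compound 3 gave only a limit of the assay and not a number: the limit of > 10000 nM in this assay, at which 1 of the 3 values shown sits.

Among the compounds shown here, this is the first measured look at chain length at this position, and moving to (oxan-4-yl)methyl in place of oxan-4-yl gives an at least 2.0-fold higher number from compound 2 to compound 3 (0.30 log units; that floor lies within the scatter), so the longer chain brought no measurable gain, yet the floor of this step alone does not establish a real loss. The wider comparison is clearer: an at least 20-fold higher number from compound 1 to compound 3 (1.30 log units; beyond the scatter), so the 4-hydroxycyclohexyl side chain, whose steps to both oxanyl side chains are beyond the scatter, remains the strongest of the three in this assay.

As far as these compounds go, how far the true value of compound 3 lies past its limit stays unknown, and with it the real size of the penalty, if any, for the longer chain. Also open, from the compounds shown here alone, is whether a 2-(4-hydroxycyclohexyl)ethyl group would keep the level of the shorter hydroxycyclohexyl side chain, and whether an amine or a carboxylic acid could stand in place of the hydroxyl on that ring.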